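This account rests on a few compounds, and the source may have more. Where it says the series, first, only, none or still open, it means among the compounds named here.

Compound 1 `CN1CCN(c2nc(-c3cccc(Cl)c3)nc3[nH]cnc23)CC1` is the reference point of the series. In an assay on cells for displacement of a labelled ligand from adenosine receptor A1 (Homo sapiens), read by scintillation counting and radioligand binding, with a stated time of 60 min, tested at 10 uM (on this read-out lower numbers stand for less inhibition and higher numbers for more inhibition at the one concentration tested (going by the name of the read-out)), compound 1 gives > 80%, a limit of the assay rather than a number. Compound 2 `CN1CCN(c2nc(-c3cc(Cl)ccc3Cl)nc3[nH]cnc23)CC1` gives > 80%, also a limit. Compound 3 `CN1CCN(c2nc(-c3cccc(O)c3)nc3[nH]cnc23)CC1` gives > 80%, again a limit. The steps a step that the two limits leave unreadable from compound 1 to compound 2, a step that the two limits leave unreadable from compound 1 to compound 3 and a step that the two limits leave unreadable from compound 2 to compound 3 are thus of unreadable size, since (the limit of > 80% in this assay, at which 3 of the 3 values shown sit). Compound 4 `Clc1cccc(-c2nc(N3CCCCC3)c3nc[nH]c3n2)c1` is not yet measured; it differs from compound 1 by piperidin-1-yl in place of 4-methylpiperazin-1-yl on an aromatic carbon. Among the compounds with values here, no measured step touches this part of the shared core, so nothing here bears on the direction or size of the change. The step is expected to be a number at least 5 percentage points lower from compound 1 to compound 4 (that floor lies within the scatter). Compound 4 is accordingly estimated at 75%, between 45% and 95%, with a fair chance of returning only a limit.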

Compound 4, a percentage reported as inhibition, at one concentration (the size of the read-out at that concentration, not a potency): > 80%
Compound 4 was reported as a limit (the forecaster's own chance of this, stated with the estimate: 45%); middle value at least 5 percentage points away from the limit.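

No size can be read for the step between compound 1 and compound 4, because both results are limits: the limit of > 80% in this assay, at which 4 of the 4 values shown sit.

Left open is whether piperidin-1-yl in place of 4-methylpiperazin-1-yl changes inhibition at all, and how compound 1, compound 2, compound 3 and compound 4 rank.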